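Urea series on a shared lactone core: step to propyl

The source may report more compounds than this note shows. Statements on the series, on what has been measured and on what is new or still open speak of the compounds shown alone.

Measured so far:
compound 1 `O=C(Nc1ccccc1)Nc1ccc2c(c1)COC2=O`: 7090 nM
compound 2 `O=C(Nc1ccc(I)cc1)Nc1ccc2c(c1)COC2=O`: 1370 nM

In a functional assay on cells (T-cell, Mus musculus) for inhibition (a lower number here means a stronger inhibitor, a higher number a weaker inhibitor), compound 2 gives the lowest of the two numbers; compound 1 gives the next one, and the step from there is a 5.2-fold lower number from compound 1 to compound 2 (0.71 log units; beyond the scatter). Compound 3 `CCCNC(=O)Nc1ccc2c(c1)COC2=O` carries propyl in place of 4-iodophenyl on an amide-type nitrogen. Among the measured compounds shown here, no measured step removes or replaces an aryl group, so the only bearing is indirect: the step of a 5.2-fold lower number from compound 1 to compound 2 (0.71 log units; beyond the scatter) shows that the group on the iodine-bearing ring matters, and taking that ring away altogether leaves no ground to expect the gain to hold. Compound 3 is therefore expected to give 9000 nM (range 2500 nM to 35000 nM), an estimated step of a 6.6-fold higher number from compound 2 to compound 3 (0.82 log units; beyond the scatter).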

Compound 3, half-maximal inhibitory concentration: 58100 nM
Compound 3: the middle estimate sits 6.5-fold (0.81 log units) below what was measured; the whole stated range lies below it.
By their numbers in this assay, from the lowest: compound 2; then compound 1; then compound 3.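

In this assay, the group on the amide-type nitrogen matters beyond the iodo substituent: replacing 4-iodophenyl with propyl gives a 42-fold higher number from compound 2 to compound 3 (1.63 log units; beyond the scatter), and replacing phenyl with propyl gives an 8.2-fold higher number from compound 1 to compound 3 (0.91 log units; beyond the scatter). Even the unsubstituted phenyl thus keeps a lower number than propyl, so the loss does not depend on iodine alone. Nothing available here accounts for these steps.

From the compounds shown here alone, whether an aromatic ring is specifically required remains open, since cyclohexyl or a longer chain such as octyl could separate ring type from group size. Whether chloro or methoxy on the phenyl ring can match iodo is also unresolved.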